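The source may hold more compounds than are shown below. What is called first, only, known or untested is meant among the compounds shown, and "the series" means these compounds.

Measured in a functional assay on HeLa cells (Homo sapiens) for cytotoxicity, read by MTT assay, with a stated time of 24 h; a higher number here means a weaker inhibitor, a lower number a stronger inhibitor:

- Compound 1 `O=c1nc2ccccn2cc1Cc1ccc(F)cc1C(F)(F)F`: 88000 nM
- Compound 2 `O=c1nc2ccc(Cl)cn2cc1Cc1ccc(F)cc1`: > 1000000 nM, a limit and not a number
- Compound 3 `O=c1nc2ccccn2cc1Cc1ccc(F)cc1`: 139000 nM

Compound 2 gives no exact reading and stands at the limit of > 1000000 nM in this assay, at which 1 of the 3 values shown sits. Compound 4 `O=c1nc2ccc(Cl)cn2cc1Cc1ccc(F)cc1C(F)(F)F` is compound 2 with one change: trifluoromethyl in place of hydrogen on an aromatic carbon. This is trifluoromethyl in place of hydrogen on an aromatic carbon of a six-membered aromatic ring of carbon only, ortho to a large group and meta to a fluoro group.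

Going by the values given here, two measured steps bear on this change. On the core without the chloro group, the same exchange gave a 1.6-fold higher number from compound 1 to compound 3 (0.20 log units; within the scatter), so no step beyond the scatter is expected in this assay for compound 4. The larger step, an at least 7.1-fold lower number from compound 2 to compound 3 (0.85 log units; beyond the scatter), concerns the chloro group, which stays in place here. This expectation rests on a single pair of compounds, and the starting point is only a limit, so it remains uncertain.

The estimated change is an at least 1.4-fold lower number from compound 2 to compound 4 (0.15 log units; that floor lies within the scatter). The expected value for compound 4 is 700000 nM, with an estimated range of 150000 nM to 2000000 nM.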

Compound 4, half-maximal inhibitory concentration: > 1000000 nM
Compound 4: a limit, no number; the forecaster's own chance of this, stated with the estimate: 50%; middle value at least 1.4-fold (0.15 log units) from the limit.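

Compound 4 gives a limit and not a number in this assay, and compound 2 also stands at a limit, so the step between them cannot be read and the size of the trifluoromethyl exchange on the chloro core stays unknown: the limit of > 1000000 nM in this assay, at which 2 of the 4 values shown sit.

What compound 4 adds is a view of the chloro group on a second core, with trifluoromethyl in place, where there is an at least 11-fold higher number from compound 1 to compound 4 (1.05 log units; beyond the scatter). Trifluoromethyl therefore does not bring the chloro compound into the readable range, and the chloro exchange moves the number in the same direction on both cores: the same change on two cores in this assay, an at least 7.1-fold lower number (0.85 log units; beyond the scatter) from compound 2 to compound 3 and an at least 11-fold lower number (1.05 log units; beyond the scatter) from compound 4 to compound 1; the limit leaves it open whether they differ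

The compounds shown leave open the true values of compound 2 and compound 4, and with them whether the chloro step differs between the two cores. They also leave open whether a methyl or methoxy group on the aromatic carbon that carries trifluoromethyl, or an amine in place of the chloro group, would give a reading that can be compared.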